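Working notes: from compound 2 to compound 4

A few compounds are considered here, and "the series" means these few. Any claim that something is new, unique, unknown or untested is made for them only; others in the source may bear on it.

For the measured compounds named here, compound 2 `COc1ccc(CN(C(=O)CSc2nc3ccccc3s2)c2cc(OC)c(OC)c(OC)c2)cc1O` gives 182 nM in a functional assay on HCT-116 cells (Homo sapiens) for antiproliferative activity, read by MTT assay, with a stated time of 48 h (a lower number here means a stronger inhibitor, a higher number a weaker inhibitor), the lowest of the three numbers known so far. Compound 1 `COc1ccc2nc(SCC(=O)N(Cc3ccc(OC)c(O)c3)c3cc(OC)c(OC)c(OC)c3)sc2c1` gives 352 nM in this assay; a 1.9-fold lower number from compound 1 to compound 2 (0.29 log units; within the scatter) is within the scatter, so the two are not told apart. Going by the values given here, compound 3 `COc1ccc(CN(C(=O)CSc2nc3cc(Br)ccc3s2)c2cc(OC)c(OC)c(OC)c2)cc1O` gives 3380 nM in this assay; a 19-fold higher number from compound 2 to compound 3 (1.27 log units; beyond the scatter) and a 9.6-fold higher number from compound 1 to compound 3 (0.98 log units; beyond the scatter) are the only steps beyond the scatter, and both concern the shared core rather than the side arm.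

Compound 4 `COc1ccc(CN(C(=O)CSc2nc3ccccc3s2)c2cc(OC)c(OC)c(OC)c2)cc1C(F)(F)F` differs from compound 2 by trifluoromethyl in place of hydroxy on an aromatic carbon. Among the compounds with values here, no measured step touches this part of the molecule; the known steps bear on the core only and give no direct guide here. The expectation is therefore cautious: a modest weakening in this assay, with wide bounds. Compound 4 is estimated at 500 nM in this assay, with a range from 150 nM to 2000 nM. The step expected is a 2.7-fold higher number from compound 2 to compound 4 (0.44 log units; beyond the scatter).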

Compound 4, half-maximal inhibitory concentration: > 80000 nM
Compound 4 ended at the assay's limit (the forecaster's own chance of this, stated with the estimate: 5%); middle value at least 160-fold (2.20 log units) from the limit.
By their numbers in this assay, from the lowest: compounds 2 and 1 (each within the scatter of the next); then compound 3. At a limit, above all of these: compound 4.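

The earlier steps shown here touched only the shared core, whereas this change, 3-hydroxy-4-methoxyphenyl to 4-methoxy-3-(trifluoromethyl)phenyl, shows that the side arm also governs the read-out in this assay, giving an at least 430-fold higher number from compound 2 to compound 4 (2.64 log units; beyond the scatter) from a single replacement. Compound 4 stands at a limit of the assay and not at a number: the limit of > 80000 nM in this assay, at which 1 of the 4 values shown sits. As far as these compounds go, the step is therefore a lower bound, and its true size is unknown, but the position, ortho to a methoxy group, clearly does not tolerate this exchange.

One change both removes the hydroxy and brings in the trifluoromethyl, so the compounds shown cannot tell which of the two accounts for the loss. From the compounds shown here alone, what an amine or a carboxylic acid would give at this position also remains open.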